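A few compounds are considered here, and "the series" means these few. Any claim that something is new, unique, unknown or untested is made for them only; others in the source may bear on it.

Of the compounds shown here, three with a shared core have been tested in a functional assay on A549 cells (Homo sapiens) for antiproliferative activity, read by sulforhodamine B assay, with a stated time of 3 days; on this read-out higher numbers stand for weaker inhibition of growth and lower numbers for stronger inhibition of growth. Compound 1 (`O=C(Nc1nccs1)c1cccc(Nc2ncc(F)c(Nc3ccc(F)cc3)n2)c1`) gives > 10000 nM, which is a limit of the assay. Compound 3 (`CN(C)c1ccc(C(=O)Nc2cccc(Nc3ncc(F)c(Nc4ccc(F)cc4)n3)c2)cc1`) gives > 10000 nM, again a limit. Among the compounds with values here, compound 2 (`O=C(c1cccc(Nc2ncc(F)c(Nc3ccc(F)cc3)n2)c1)N1CCCCC1`) gives 13200 nM, the only actual number of the three. Compound 4 (`O=C(Nc1cc(Cl)cc(Cl)c1)c1cccc(Nc2ncc(F)c(Nc3ccc(F)cc3)n2)c1`) differs from compound 2 as follows: (3,5-dichlorophenyl)amino in place of piperidin-1-yl on a carbonyl carbon. Thus (3,5-dichlorophenyl)amino stands in place of piperidin-1-yl on a carbonyl carbon. Within the data shown here, the one measured step, a step that the limit leaves unreadable from compound 1 to compound 2, offers no size to carry over. Compound 4 shares an amino group on that carbonyl carbon with compound 1, so the nearest guide is the limit of > 10000 nM in this assay, at which 2 of the 3 values shown sit. No step beyond the scatter is expected, and the estimated step is a 1.5-fold lower number from compound 2 to compound 4 (0.17 log units; within the scatter). For compound 4 the estimated value is 9000 nM, with an expected range of 3000 nM to 27000 nM.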

Compound 4, concentration for 50% growth inhibition: 17500 nM
Beside the measured number, compound 4's estimate is 1.9-fold (0.29 log units) below it; the measured number falls inside the stated range.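

In this assay, within the data shown here, the change on the carbonyl carbon gives a 1.3-fold higher number from compound 2 to compound 4 (0.12 log units; within the scatter), so the first readable comparison at this position shows that an aromatic ring with an amide hydrogen and the non-aromatic piperidin-1-yl cannot be told apart. Both numbers lie close to one mark: the limit of > 10000 nM in this assay, at which 2 of the 4 values shown sit. The step from compound 1 to compound 4 cannot be read. From the compounds shown here alone, whether a carboxylic acid or a morpholin-4-yl on that carbonyl carbon would give a clearly lower number stays open, as does the effect of changing the fluorines on the shared core.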